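Aryl exchange from compound 3 to compound 4

A few compounds are considered here, and "the series" means these few. Any claim that something is new, unique, unknown or untested is made for them only; others in the source may bear on it.

In a functional assay on SK-OV-3 cells (Homo sapiens) for cytotoxicity (on this read-out higher numbers stand for weaker inhibition and lower numbers for stronger inhibition), compound 1 `C=C/C=C\[C@H](C)[C@H](OC(N)=O)[C@@H](C)[C@H](O)[C@@H](C)C/C(C)=C\[C@H](C)[C@@H](O)[C@@H](C)/C=C\CCc1cccc(F)c1` gives 400 nM while compound 2 `C=C/C=C\[C@H](C)[C@H](OC(N)=O)[C@@H](C)[C@H](O)[C@@H](C)C/C(C)=C\[C@H](C)[C@@H](O)[C@@H](C)/C=C\CCc1cccc(O)c1C` gives 270 nM and compound 3 `C=C/C=C\[C@H](C)[C@H](OC(N)=O)[C@@H](C)[C@H](O)[C@@H](C)C/C(C)=C\[C@H](C)[C@@H](O)[C@@H](C)/C=C\CCc1ccc(C)c(O)c1` gives 410 nM on the same read-out. All three lie within the scatter of one another, so compound 3 stands level with both neighbours, and a 1.5-fold lower number from compound 1 to compound 2 (0.17 log units; within the scatter) is also within the scatter.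

Compound 4 `C=C/C=C\[C@H](C)[C@H](OC(N)=O)[C@@H](C)[C@H](O)[C@@H](C)C/C(C)=C\[C@H](C)[C@@H](O)[C@@H](C)/C=C\CCc1cc(F)cc(F)c1` carries 3,5-difluorophenyl in place of 3-hydroxy-4-methylphenyl on a saturated chain carbon, two bonds along the chain from a double-bonded chain carbon.

Within the data shown here, two measured steps bear on this exchange: a 1.0-fold higher number from compound 1 to compound 3 (0.01 log units; within the scatter) and a 1.5-fold higher number from compound 2 to compound 3 (0.18 log units; within the scatter) are both within the scatter. The first is the closer guide, as it exchanges 3-fluorophenyl for the same 3-hydroxy-4-methylphenyl. Among the measured compounds shown here, no measured compound carries 3,5-difluorophenyl, which widens the range.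

The estimated step is a 1.1-fold lower number from compound 3 to compound 4 (0.03 log units; within the scatter) and none beyond the scatter is expected in this assay here. The expected value for compound 4 is 380 nM with an estimated range from 170 nM to 850 nM for repeated measurements.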

Compound 4, half-maximal inhibitory concentration: 360 nM
Beside the measured number, compound 4's estimate is 1.1-fold (0.02 log units) above it; low and high end bracket the measured number.
By their numbers in this assay, from the lowest: compounds 2, 4, 1 and 3 (each within the scatter of the next).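

In this assay, fluoro in place of hydrogen on an aromatic carbon gives a 1.1-fold lower number from compound 1 to compound 4 (0.05 log units; within the scatter) and so leaves the number level at this place on a saturated chain carbon, two bonds along the chain from a double-bonded chain carbon. 3,5-Difluorophenyl, with 0 hydrogen-bond donors and 0 hydrogen-bond acceptors, also stands level with both hydroxy-bearing aryl groups, giving a 1.1-fold lower number from compound 3 to compound 4 (0.06 log units; within the scatter) and a 1.3-fold higher number from compound 2 to compound 4 (0.12 log units; within the scatter), so all four aryl groups shown now lie within the scatter of one another. No measurement is available that explains this level picture.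

Every step shown lies within the scatter, so it remains open whether any change at this place can move the number beyond it. A phenyl ring carrying an amine or a carboxylic acid, or a longer chain in place of the 2-(3,5-difluorophenyl)ethyl group, would test that.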